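The source may hold more compounds than are shown below. What is called first, only, known or untested is meant among the compounds shown, and "the series" means these compounds.

Measured so far:
Compound 1, `CNc1nccc(N2CC[C@H](NC(=O)Nc3ccc(CN(C)C)c(C(F)(F)F)c3)C2)n1`: 91%
Compound 2, `CNc1nccc(N2CC[C@H](NC(=O)Nc3ccc(C)c(Cl)c3)C2)n1`: 98.9%

Both numbers come from an ADME assay on a cell-free system (plasma, Rattus norvegicus) for protein binding. Among the measured compounds shown here, of the two, compound 1 is the one with more free compound; compound 2, at 98.9%, has a markedly smaller unbound fraction, and this gap lies well beyond the usual scatter of the measurement.

Compound 3, `CNc1nccc(N2CC[C@H](NC(=O)Nc3ccc(CN4CCCC4)c(C(F)(F)F)c3)C2)n1`, has not been measured yet. It differs from compound 1 in a single place: pyrrolidin-1-yl in place of dimethylamino on a saturated chain carbon bound to an aromatic carbon. The shared core, the urea linkage and the trifluoromethyl group stay as they are; only the group on the saturated chain carbon bound to the aromatic carbon is exchanged.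

For the measured compounds named here, no pair of measured compounds shows this exchange, so no measured step can be used to gauge it. The expectation is a modest rise in binding, still within the usual scatter of repeated measurements: a 1.3-fold lower unbound fraction from compound 1 to compound 3 (0.11 log units; within the scatter) is the step that this estimate means. For compound 3 the expected value in this assay is 93%, with a range from 87% to 97%.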

Compound 3, plasma protein binding: 87.8%
Compound 3: middle estimate off by 1.7-fold (0.24 log units) (unbound fraction), on the low side; measured number inside the range.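

Until now the compounds shown held no pair differing in one place, so this is the first reading of a single exchange in this assay. Putting pyrrolidin-1-yl in place of dimethylamino on a saturated chain carbon bound to an aromatic carbon gives a 1.4-fold higher unbound fraction from compound 1 to compound 3 (0.13 log units; within the scatter). At this place, then, a five-membered non-aromatic ring of 5 heavy atoms can stand in for a ringless group of 3 heavy atoms without a difference that this measurement can separate from its usual scatter, and no supporting data bear on why the two groups read alike.

On these data alone, whether this holds for other groups on the same carbon stays open: a morpholine ring, which carries an oxygen atom in the ring, a carboxylic acid, or a longer chain carrying the nitrogen could each read differently. One exchange on one compound also cannot tell how the same swap would read with another group in place of the trifluoromethyl group or on a different core.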